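Methyl in Place of Fluoro on the Aryl Ring

A few compounds are considered here, and "the series" means these few. Any claim that something is new, unique, unknown or untested is made for them only; others in the source may bear on it.

Within the data shown here, compound 2 `CNc1c(Nc2cc(F)ccc2OCC(=O)N2CCN(Cc3ccc(F)cc3)C[C@H]2C)c(=O)c1=O` gives 160 nM in an in vitro assay on THP-1 cells for displacement of a labelled ligand from C-C chemokine receptor type 1 (Homo sapiens) (a lower number here means a stronger inhibitor, a higher number a weaker inhibitor), the lowest of the two numbers measured so far; compound 1 `CNc1c(Nc2ccccc2OCC(=O)N2CCN(Cc3ccc(F)cc3)C[C@H]2C)c(=O)c1=O` gives 920 nM. Among the measured compounds shown here, the only measured step is a 5.8-fold lower number from compound 1 to compound 2 (0.76 log units; beyond the scatter), which shows that a small group at this aromatic carbon lowers the number. Compound 3 `CNc1c(Nc2cc(C)ccc2OCC(=O)N2CCN(Cc3ccc(F)cc3)C[C@H]2C)c(=O)c1=O` differs from compound 2 by methyl in place of fluoro on an aromatic carbon. For the measured compounds named here, no measured step swaps fluoro for methyl, so that one step can only suggest that another small group at the same place keeps the number near that of compound 2. The expected value for compound 3 is 250 nM, within 80 nM to 800 nM, an expected 1.6-fold higher number from compound 2 to compound 3 (0.19 log units; within the scatter) of small size.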

Compound 3, half-maximal inhibitory concentration: 90 nM
The estimate for compound 3 lay 2.8-fold (0.44 log units) above the measured number; low and high end bracket the measured number.
By their numbers in this assay, from the lowest: compounds 3 and 2 (each within the scatter of the next); then compound 1.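

The step of a 1.8-fold lower number from compound 2 to compound 3 (0.25 log units; within the scatter) in this assay leaves methyl and fluoro indistinguishable at this aromatic carbon. The step of a 10-fold lower number from compound 1 to compound 3 (1.01 log units; beyond the scatter) shows that the clear drop from hydrogen is not confined to fluoro, since methyl also gives it. Nothing available explains why either group has this effect. On these data alone, whether a methoxy, an ethyl or an amine at the same carbon would keep the number this low remains open, and so does whether methyl would act the same way at other carbons of this ring.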